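The compounds below may be only part of what the source reports. "The series", "measured", "known", "first", "only" and "open" are said of these compounds alone.

Measured in an ADME assay on NHDF cells (Homo sapiens) for cytotoxicity, read by MTT assay, with a stated time of 72 h (on this read-out lower numbers stand for stronger inhibition and higher numbers for weaker inhibition), so far:
- compound 1 `COc1ccc(/C=C2\CCC/C(=C\c3ccccc3Cl)C2=O)cc1OC` gives 21600 nM
- compound 2 `COc1ccc(/C=C2\CCC/C(=C\c3cccc(Br)c3)C2=O)cc1OC` gives 12400 nM
- compound 3 `COc1ccc(/C=C2\CCC/C(=C\c3cccc(O)c3)C2=O)cc1OC` gives 6800 nM

Compound 3 stands at 6800 nM in this set. There is a 3.2-fold lower number from compound 1 to compound 3 (0.50 log units; beyond the scatter), but only a 1.8-fold lower number from compound 2 to compound 3 (0.26 log units; within the scatter).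

Compound 4 `COc1ccc(/C=C2\CCC/C(=C\c3ccc(O)c(Cl)c3)C2=O)cc1OC` changes one group on the shared core: 3-chloro-4-hydroxyphenyl in place of 3-hydroxyphenyl on a double-bonded chain carbon bound to a double-bonded ring carbon. Within the data shown here, none of the measured compounds carries the 3-chloro-4-hydroxyphenyl group, so only the swaps at this place bear on it. Among these, there is a 1.7-fold lower number from compound 1 to compound 2 (0.24 log units; within the scatter), and the largest swap remains the modest one from compound 1 to compound 3.

No step beyond the scatter is therefore expected in this assay. The expected change is a 1.2-fold higher number from compound 3 to compound 4 (0.07 log units; within the scatter). For compound 4 the estimated value is 8000 nM, with an expected range from 3500 nM to 18000 nM.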

Compound 4, half-maximal inhibitory concentration: 21900 nM
Compound 4: middle estimate off by 2.7-fold (0.44 log units), on the low side; measured number outside the range, above it.
By their numbers in this assay, from the lowest: compounds 3, 2, 1 and 4 (each within the scatter of the next, the first and the last beyond it).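

At this place in this assay, 3-chloro-4-hydroxyphenyl in place of 3-hydroxyphenyl gives a 3.2-fold higher number from compound 3 to compound 4 (0.51 log units; beyond the scatter), so carrying a hydroxy on this ring does not by itself keep the number low. The other two steps, a 1.8-fold higher number from compound 2 to compound 4 (0.25 log units; within the scatter) and a 1.0-fold higher number from compound 1 to compound 4 (0.01 log units; within the scatter), both stay within the scatter, which leaves only compound 3 apart from compound 4. No evidence here bears on the cause of this step.

Whether the chloro or the placing of the hydroxy accounts for the step stays open. So does what an aminophenyl or a carboxyphenyl group would give at this place.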